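The compounds below may be only part of what the source reports. "The series", "measured", "known", "first", "only" and "open" are said of these compounds alone.

In an ADME assay on HEK293 cells (Homo sapiens) for cytotoxicity, read by reporter gene assay and resazurin assay, with a stated time of 48 h (on this read-out higher numbers stand for lower toxicity in this test and lower numbers for higher toxicity in this test), compound 1 `O=C(Nc1ccc(Sc2nc3ccccc3s2)cc1)c1ccccc1O` gives 74000 nM and compound 2 `O=C(Nc1ccc(Sc2nc3ccccc3s2)cc1)c1cc(Br)cc(Br)c1O` gives 66000 nM. These two numbers lie within the scatter of each other, so compound 2 holds no distinct place in this small set. Compound 3 `O=C(Nc1ccc(Sc2nc3ccccc3s2)cc1)c1cccc(Br)c1` keeps the shared core and differs from compound 2 only in the group on a carbonyl carbon whose other neighbour is an amide-type nitrogen: 3-bromophenyl in place of 3,5-dibromo-2-hydroxyphenyl on a carbonyl carbon. In words, 3-bromophenyl stands in place of 3,5-dibromo-2-hydroxyphenyl. For the measured compounds named here, only one measured step bears on this change: a 1.1-fold lower number from compound 1 to compound 2 (0.05 log units; within the scatter). Going by the values given here, that step concerns the same place on the molecule, but both of its compounds carry a hydroxy group, and no measured compound lacks one, so the evidence is thin. Among the compounds with values here, with only that small step to go on, no shift beyond the scatter is expected in this assay, and the estimated change is a 1.0-fold lower number from compound 2 to compound 3 (0.01 log units; within the scatter). For compound 3 the expected value is 65000 nM, with an estimated range from 28000 nM to 130000 nM.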

Compound 3, half-maximal cytotoxic concentration: 74000 nM
For compound 3 the middle estimate is 1.1-fold (0.06 log units) below the measured one; measured number inside the range.
By their numbers in this assay, from the lowest: compounds 2, 1 and 3 (each within the scatter of the next).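

For the compounds shown here, compound 3 is the first compound whose group on the carbonyl carbon carries no hydroxy group, which gives the earlier question about that group its first test in this assay: the result is a 1.1-fold higher number from compound 2 to compound 3 (0.05 log units; within the scatter), and the comparison with the unbrominated phenol gives no change at the digits printed from compound 1 to compound 3 (within the scatter). Across these three compounds, 2-hydroxyphenyl, 3,5-dibromo-2-hydroxyphenyl and 3-bromophenyl on this carbonyl carbon all give numbers within the scatter of each other, so neither the hydroxy group nor the number of bromine atoms separates them in this test. No accompanying measurement offers an account of these numbers.

What the compounds shown leave open is whether any group at this place moves the number beyond the scatter, for example an amine, a carboxylic acid or a longer chain in place of the substituted phenyl ring. They also leave open whether the unsubstituted phenyl group would stand with these three, and whether the shared core, which all three keep, sets the level of the number in this assay.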